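A few compounds are considered here, and "the series" means these few. Any claim that something is new, unique, unknown or untested is made for them only; others in the source may bear on it.

Working notes on the series. In a functional assay on BGC-823 cells (Homo sapiens) for cytotoxicity, read by MTT assay (a higher number here means a weaker inhibitor, a lower number a stronger inhibitor), compound 2 `COc1cccc(/C=C/C(=O)c2sc(Nc3ccccc3)nc2C)c1` gives 14300 nM. Compound 1 `COc1cccc(/C=C/C(=O)c2sc(Nc3ccc(Cl)cc3)nc2C)c1` returns only a limit of the assay, > 25000 nM. The change between these two, (chloro in place of hydrogen on an aromatic carbon), reads as an at least 1.7-fold higher number from compound 2 to compound 1 (0.24 log units; that floor lies within the scatter). Compound 3 `Cc1nc(Nc2cccc(Cl)c2)sc1C(=O)/C=C/c1ccc(Cl)cc1` also returns only a limit in this assay, > 25000 nM. How the core of compound 3 differs from the core of compound 2 is not broken down here. Compound 4 `Cc1nc(Nc2ccc(Cl)c(Cl)c2)sc1C(=O)/C=C/c1ccc(Cl)cc1` has not yet been measured in this assay; it differs from compound 3 by chloro in place of hydrogen on an aromatic carbon. This is the same kind of change as from compound 2 to compound 1, though here the place is ortho to a chloro group (1 heavy atom), which the earlier pair does not share. Of the three known values, two sit at the limit, (the limit of > 25000 nM in this assay, at which 2 of the 3 values shown sit). The step from compound 3 to compound 4 is expected to be a step that the limit leaves unreadable from compound 3 to compound 4, resting on the direction of an at least 1.7-fold higher number from compound 2 to compound 1 (0.24 log units; that floor lies within the scatter) toward weaker inhibition. Compound 4 is therefore estimated near 40000 nM, between 12000 nM and 150000 nM, and will most probably be reported only as a limit.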

Compound 4, half-maximal inhibitory concentration: 22700 nM
Compound 4: the middle estimate sits 1.8-fold (0.25 log units) above what was measured; the range from low to high includes it.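

In this assay the change of chloro in place of hydrogen on an aromatic carbon, here 3-chlorophenyl to 3,4-dichlorophenyl, reads as an at least 1.1-fold lower number from compound 3 to compound 4 (0.04 log units; that floor lies within the scatter). The two steps point in opposite directions on paper, but this shows neither that the change carries from one core to the other nor that it fails to carry: the same change on two cores in this assay, an at least 1.7-fold higher number (0.24 log units; that floor lies within the scatter) from compound 2 to compound 1 and an at least 1.1-fold lower number (0.04 log units; that floor lies within the scatter) from compound 3 to compound 4; the limit leaves it open whether they differ Each step has a limit of the assay at one end, so each gives only a floor and not a size, and the series offers little room to read such steps: the limit of > 25000 nM in this assay, at which 2 of the 4 values shown sit.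

The compounds shown leave open how the same aromatic carbon would respond to a group other than chloro, such as an amine or a carboxylic acid. They also leave open whether the chloro change would give the same step on both cores if every compound in the two pairs carried a number, not a limit.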